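Cyano in place of carbamoyl: expected effect on HL-60 inhibition

The source may hold more compounds than are shown below. What is called first, only, known or untested is meant among the compounds shown, and "the series" means these compounds.

Measured so far in a functional assay on HL-60 cells (Homo sapiens) for inhibition, read by MTT assay, with a stated time of 72 h; on this read-out higher numbers stand for weaker inhibition and lower numbers for stronger inhibition:
compound 1 `Cc1nc(-c2ccccc2)c(C(=O)N2CCN(c3cccc(C(N)=O)c3)CC2)o1`: 71 nM
compound 2 `Cc1nc(-c2ccccc2Cl)c(C(=O)N2CCN(c3cccc(Cl)c3)CC2)o1`: 132 nM
compound 3 `COc1cc(OC)cc(N2CCN(C(=O)c3onc(C)c3-c3ccccc3)CC2)c1`: 152 nM

Of the compounds shown here, three have numbers so far. Compound 1 and compound 2 give values that lie within the usual scatter of each other, so nothing separates them with confidence. Compound 3 gives a number that lies beyond the scatter from compound 1, so compound 1 inhibits more strongly than compound 3 in this assay. Among the compounds with values here, no two of these three compounds differ in just one place, so no single-change step is available to lean on.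

Compound 4 `Cc1nc(-c2ccccc2)c(C(=O)N2CCN(c3cccc(C#N)c3)CC2)o1` is not yet measured. It differs from compound 1 in one place: cyano in place of carbamoyl on an aromatic carbon. The carbamoyl group carries a hydrogen-bond donor that the cyano group does not, while both carry one hydrogen-bond acceptor. Within the data shown here, with no measured step of this kind at hand, the expectation rests on the change itself. A small step is expected, if anything towards a slightly higher number, and it may well stay within the scatter; the expected step is a 1.4-fold higher number from compound 1 to compound 4 (0.15 log units; within the scatter). Compound 4 is therefore estimated at 100 nM, with a range from 35 nM to 300 nM.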

Compound 4, half-maximal inhibitory concentration: 39.6 nM
For compound 4 the middle estimate is 2.5-fold (0.40 log units) above the measured one; the range from low to high includes it.
By their numbers in this assay, from the lowest: compounds 4, 1, 2 and 3 (each within the scatter of the next, the first and the last beyond it).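

In this assay the change from 3-carbamoylphenyl to 3-cyanophenyl gives a 1.8-fold lower number from compound 1 to compound 4 (0.25 log units; within the scatter) and so leaves the two compounds indistinguishable on this read-out. This first single-change step in the set shows that, at this place on the ring, the hydrogen-bond donor of the carbamoyl group can go without a loss of inhibition beyond the scatter, while the hydrogen-bond acceptor count stays the same and the step therefore cannot show whether an acceptor matters here. No measurement comes with the result that could explain this step.

As far as these compounds go, it remains open whether a group with no hydrogen-bond acceptor, such as methyl, or a charged one, such as a carboxylic acid or an aminomethyl group, would move the number at this place beyond the scatter. The compounds shown also do not tell whether cyano in place of carbamoyl would behave the same way on the different cores of compound 2 and compound 3.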